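Replacing a difluorophenyl with a methoxyphenyl on the chain

The source may report more compounds than this note shows. Statements on the series, on what has been measured and on what is new or still open speak of the compounds shown alone.

Compound 1, `O=C(/C(=C\c1ccc(F)cc1F)Sc1ccc(Br)cc1)c1ccc(Br)cc1`, in a functional assay on DU-145 cells (Homo sapiens) for inhibition, read by trypan blue exclusion, with a stated time of 96 h (on this read-out lower numbers stand for stronger inhibition of growth and higher numbers for weaker inhibition of growth), gives 1000 nM.
Compound 2, `Cc1ccc(S/C(=C/c2ccc(F)cc2C(F)(F)F)C(=O)c2ccc(Br)cc2)cc1`, in this assay gives 25000 nM.
Compound 3, `Cc1ccc(S/C(=C/c2ccc(F)cc2F)C(=O)c2ccc(Br)cc2)cc1`, in this assay reaches only the limit > 100000 nM.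

Compound 3 thus stands at the weak end of the three, with a limit rather than a number, as the limit of > 100000 nM in this assay, at which 1 of the 3 values shown sits, records. The step of an at least 100-fold higher number from compound 1 to compound 3 (2.00 log units; beyond the scatter) reaches that limit. The step of an at least 4.0-fold higher number from compound 2 to compound 3 (0.60 log units; beyond the scatter) also ends at it.

Compound 4, `COc1ccccc1/C=C(/Sc1ccc(C)cc1)C(=O)c1ccc(Br)cc1`, differs from compound 3 in one place: 2-methoxyphenyl in place of 2,4-difluorophenyl on a double-bonded chain carbon bound to a double-bonded chain carbon. Within the data shown here, no measured step alters this same group in this way; the step of an at least 4.0-fold higher number from compound 2 to compound 3 (0.60 log units; beyond the scatter) changes a substituent on the ring that is exchanged here, but swaps fluoro for trifluoromethyl rather than the whole ring for a 2-methoxyphenyl. With compound 3 at a limit, no direction beyond the scatter can be read from the data, so compound 4 is expected to stay near that limit, a step of a number no higher from compound 3 to compound 4 (the limit leaves the size open). Compound 4 is therefore estimated at 100000 nM, within 30000 nM to 300000 nM.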

Compound 4, concentration for 50% growth inhibition: 9000 nM
Beside the measured number, compound 4's estimate is 11-fold (1.05 log units) above it, outside the stated range (below it).
By their numbers in this assay, from the lowest: compound 1; then compound 4; then compound 2. At a limit, above all of these: compound 3.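

In this assay, the ring on the double-bonded chain carbon tolerates being exchanged whole: 2-methoxyphenyl in place of 2,4-difluorophenyl gives an at least 11-fold lower number from compound 3 to compound 4 (1.04 log units; beyond the scatter). The earlier compounds had shown this ring changing only in a substituent, fluoro for trifluoromethyl, whereas compound 4 shows that a ring with no fluorine at all gives a measured growth inhibition while the methyl on the other side stays in place. The size of this gain remains open-ended, and compound 3 stands as a limit and not a number: the limit of > 100000 nM in this assay, at which 1 of the 4 values shown sits.

The compounds shown leave open whether the gain belongs to the methoxy group itself or to the loss of the fluoro groups, and whether a hydroxyl or an amine on this ring would do the same. They also leave open whether the exchange holds with bromo in place of methyl, the change that separates compound 1 from compound 3.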